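Fluorophenyl in Place of Naphthyl on the Shared Core

A few compounds are considered here, and "the series" means these few. Any claim that something is new, unique, unknown or untested is made for them only; others in the source may bear on it.

Among the compounds with values here, compound 3 `c1ccc2c(-c3cn4ccnc4c(-c4ccc5ncn(C6CCCCC6)c5c4)n3)cccc2c1` gives 4.32% in a functional assay on NCI-H23 cells (Homo sapiens) for inhibition, read by sulforhodamine B assay, with a stated time of 48 h, tested at 10 uM (a higher number here means more inhibition at the concentration tested (going by the name of the read-out), a lower number less inhibition), the lowest of the three numbers measured so far. Compound 1 `c1ccc(-c2cn3ccnc3c(-c3ccc4ncn(C5CCCCC5)c4c3)n2)cc1` gives 45.3% in this assay, and compound 2 `COc1ccc(-c2cn3ccnc3c(-c3ccc4ncn(C5CCCCC5)c4c3)n2)cc1` gives 62.2%. The two steps that end at compound 3 were both large: a number 41 percentage points lower from compound 1 to compound 3 (beyond the scatter) and a number 57.9 percentage points lower from compound 2 to compound 3 (beyond the scatter), whereas a number 16.9 percentage points higher from compound 1 to compound 2 (beyond the scatter) was only modest.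

Compound 4 `Fc1ccc(-c2cn3ccnc3c(-c3ccc4ncn(C5CCCCC5)c4c3)n2)cc1` differs from compound 3 in one place: 4-fluorophenyl in place of naphthalen-1-yl on an aromatic carbon. This change runs against the direction of the large steps, since it takes out the naphthalen-1-yl group and puts a 4-fluorophenyl group, a single carbon ring like the phenyl of compound 1 and the 4-methoxyphenyl of compound 2, in its place. Within the data shown here, a large rise in this assay is therefore expected, comparable in size to the fall seen in a number 41 percentage points lower from compound 1 to compound 3 (beyond the scatter), though the data give no measured step for a fluorine on that ring. Compound 4 is estimated to give 48%, with a range of 28% to 68%, which would mean an expected step of a number 43.7 percentage points higher from compound 3 to compound 4 (beyond the scatter).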

Compound 4, a percentage reported as inhibition, at one concentration (the size of the read-out at that concentration, not a potency): 2.36%
For compound 4 the middle estimate is 45.6 percentage points above the measured one; the whole stated range lies above it.
By their numbers in this assay, from the lowest: compounds 4 and 3 (each within the scatter of the next); then compound 1; then compound 2.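

In this assay the result shows that a single ring at this position does not by itself keep the number up, since 4-fluorophenyl and naphthalen-1-yl cannot be told apart here (a number 2 percentage points lower from compound 3 to compound 4 (within the scatter)). It also shows that the substituent on the phenyl ring matters, as one fluoro in place of hydrogen gives a large step (a number 42.9 percentage points lower from compound 1 to compound 4 (beyond the scatter)) and fluoro in place of methoxy gives another (a number 59.8 percentage points lower from compound 2 to compound 4 (beyond the scatter)), while compound 1 and compound 2 alone had shown only a modest step on that ring. Nothing available here explains why fluoro has so large an effect.

Left open is how other groups on this ring would read, such as chloro, hydroxy, ethoxy or dimethylamino. Going by these compounds, whether the order of these four compounds would hold at other concentrations also remains open.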